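From isobutoxy to pentyloxy on a shared core

This account rests on a few compounds, and the source may have more. Where it says the series, first, only, none or still open, it means among the compounds named here.

compound 1, `C[S+]([O-])/C=C/c1cc(=O)c2cc(C#N)ccc2o1`: > 10000 nM
compound 2, `C[S+]([O-])/C=C/c1cc(=O)c2ccccc2o1`: 1900 nM
compound 3, `CC(C)COc1ccc2oc(/C=C/[S+](C)[O-])cc(=O)c2c1`: 1100 nM

In a functional assay on A549 cells (Homo sapiens) for cytotoxicity, with a stated time of 48 h (on this read-out lower numbers stand for stronger inhibition and higher numbers for weaker inhibition), compound 1 reaches only the assay limit of > 10000 nM and so carries no number. Compound 2 gives 1900 nM, and compound 3 gives 1100 nM, the lowest of the two numbers, though the step of a 1.7-fold lower number from compound 2 to compound 3 (0.24 log units; within the scatter) stays within the scatter. The steps away from the limit are an at least 5.2-fold lower number from compound 1 to compound 2 (0.72 log units; beyond the scatter) and an at least 9.0-fold lower number from compound 1 to compound 3 (0.95 log units; beyond the scatter).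

Compound 4, `CCCCCOc1ccc2oc(/C=C/[S+](C)[O-])cc(=O)c2c1`, differs from compound 3 by butyl in place of isopropyl on a saturated chain carbon bound to an oxygen on an aromatic ring. Within the data shown here, the only measured step touching this chain, a 1.7-fold lower number from compound 2 to compound 3 (0.24 log units; within the scatter), lies within the scatter, and no measured pair compares chain shapes or lengths. No step beyond the scatter is therefore expected in this assay; the estimated step is a 1.1-fold lower number from compound 3 to compound 4 (0.04 log units; within the scatter). Compound 4 is thus expected at 1000 nM, between 400 nM and 2500 nM.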

Compound 4, half-maximal inhibitory concentration: 1600 nM
The estimate for compound 4 lay 1.6-fold (0.20 log units) below the measured number; the measured number falls inside the stated range.
By their numbers in this assay, from the lowest: compounds 3, 4 and 2 (each within the scatter of the next). At a limit, above all of these: compound 1.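

In this assay, a straight chain can now be compared with a branched one on the same oxygen: a 1.5-fold higher number from compound 3 to compound 4 (0.16 log units; within the scatter). Adding the pentyloxy group to the unsubstituted core also gives no clear change, with a 1.2-fold lower number from compound 2 to compound 4 (0.07 log units; within the scatter), so neither chain shape nor either ether separates from the others here. Only the swap from cyano stands out, with an at least 6.2-fold lower number from compound 1 to compound 4 (0.79 log units; beyond the scatter), and this size is only a bound since compound 1 sits at a limit: the limit of > 10000 nM in this assay, at which 1 of the 4 values shown sits.

Going by these compounds, whether a longer chain or an amine in place of these ethers would give a step beyond the scatter stays open.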